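The source may report more compounds than this note shows. Statements on the series, on what has been measured and on what is new or still open speak of the compounds shown alone.

Working notes on the series. In a functional assay on KB cells (Homo sapiens) for inhibition, read by CellTiter-Blue, with a stated time of 96 h, in the presence of a further agent that is not named here (a lower number here means a stronger inhibitor, a higher number a weaker inhibitor), compound 1 `Nc1nc2[nH]c(CCCCCCCCC(=O)N[C@@H](CCC(=O)O)C(=O)O)cc2c(=O)[nH]1` gives > 1000 nM as a limit and not a number. Compound 2 `Nc1nc2[nH]c(CCCCCC(=O)O)cc2c(=O)[nH]1` gives > 1000 nM as a limit too. Compound 3 `Nc1nc2[nH]c(CCCCCCC(=O)O)cc2c(=O)[nH]1` gives > 1000 nM as a limit as well. The set therefore rests on the limit of > 1000 nM in this assay, at which 3 of the 3 values shown sit, and no number places compound 3 within it.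

The next structure is compound 4 `Nc1nc2[nH]c(CCCCCCCC(=O)O)cc2c(=O)[nH]1`. Its change from compound 3 is carboxymethyl in place of carboxy on a saturated chain carbon, six bonds along the chain from an aromatic carbon and reads as carboxymethyl in place of carboxy on a saturated chain carbon, six bonds along the chain from an aromatic carbon.

Within the data shown here, the only measured step of the same kind is a step that the two limits leave unreadable from compound 2 to compound 3 and it is the same exchange, five bonds along the chain from an aromatic carbon. Both of its ends are limits, so it carries no size and no direction over to the new step. No step beyond the scatter can be argued for in this assay in either direction. The estimated step that the limit leaves unreadable from compound 3 to compound 4 is accordingly expected to stay unresolved, and a return of a limit is the likeliest report. Compound 4 is estimated at 2000 nM with an expected range from 1000 nM to 10000 nM in this read-out.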

Compound 4, half-maximal inhibitory concentration: > 1000 nM
Compound 4 was reported as a limit (the forecaster's own chance of this, stated with the estimate: 90%); the middle value is on the limit's open side.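

In this assay compound 4 gives > 1000 nM, a limit and not a number, so its steps from compound 2 and compound 3 cannot be read: the limit of > 1000 nM in this assay, at which 4 of the 4 values shown sit.

The compounds shown leave open where compound 1, compound 2, compound 3 and compound 4 actually lie, and whether lengthening the carboxy-ending chain changes inhibition in this assay at all.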